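A few compounds are considered here, and "the series" means these few. Any claim that something is new, unique, unknown or untested is made for them only; others in the source may bear on it.

In a functional assay on KB cells (Homo sapiens) for inhibition, read by MTT assay, with a stated time of 24 h, tested at 0.1 ug/mL (on this read-out lower numbers stand for less inhibition of growth and higher numbers for more inhibition of growth at the one concentration tested), two compounds have been measured so far.

compound 1 `O=C(CCCCC1CCSS1)Nc1ccccc1Cl` gives 5.11%
compound 2 `O=C(CCCCC(S)CCS)Nc1ccccc1` gives 9.49%

Of these two, compound 2 stands at 9.49% and compound 1 stands at 5.11% in this assay and the two numbers lie within the scatter of each other. Both sit low on this read-out, so neither compound separates from the other.

The next compound, compound 3 `O=C(CCCCC(S)CCS)Nc1ccccc1Cl` differs from compound 2 by a single change chloro in place of hydrogen on an aromatic carbon which puts chloro in place of hydrogen on an aromatic carbon, ortho to a large group. Among the compounds with values here, no two measured compounds differ in only one place, so the size of such a change has not been seen in these data. With nothing to suggest a direction, the step is expected to stay within the scatter in this assay and the starting point remains compound 2 at 9.49% in that expectation.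

The estimated move a number 0.5 percentage points higher from compound 2 to compound 3 (within the scatter) is expected to stay within the scatter. For compound 3 the estimated value is 10% with an expected range from 2% to 22% on this read-out.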

Compound 3, percent growth inhibition at one concentration: "not active" (no number reported)
For compound 3 the study gives words and no number; there is nothing to compare the estimate with.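

In this assay, within the data shown here, compound 3 is reported only in words, as not active, with no number, so no step from compound 2 to compound 3 can be read. Nothing available bears on this result. The compounds shown leave open whether chloro in place of hydrogen on the aromatic carbon moves this read-out at all, and by how much.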